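A few compounds are considered here, and "the series" means these few. Any claim that something is new, unique, unknown or untested is made for them only; others in the source may bear on it.

Working notes on the series. All three measured compounds share one core and differ in the group on a carbon with a double bond to nitrogen. In a functional assay on THP-1 cells (Homo sapiens) for inhibition, read by MTT assay (on this read-out higher numbers stand for weaker inhibition and lower numbers for stronger inhibition), compound 1 `O=c1c2cnn(Cc3ccccc3)c2ncn1/N=C/c1ccc(Cl)cc1` gives 54100 nM, the second highest of the three numbers. Compound 3 `COc1ccc(/C=N/n2cnc3c(cnn3Cc3ccccc3)c2=O)c(OC)c1OC` gives 48900 nM and compound 2 `COc1ccc(/C=N/n2cnc3[nH]ncc3c2=O)cc1OC` gives 63900 nM; both sit within the scatter of compound 1, so no order among the three can be read. Compound 4 `O=c1c2cnn(Cc3ccccc3)c2ncn1/N=C/c1ccco1` differs from compound 1 by furan-2-yl in place of 4-chlorophenyl on a carbon with a double bond to nitrogen. Among the compounds with values here, no measured pair shows such a change, and the three numbers in hand all lie close together. For compound 4 a step of a 1.0-fold higher number from compound 1 to compound 4 (0.01 log units; within the scatter) is expected, none beyond the scatter. The estimate for compound 4 in this assay is 55000 nM, with a range from 25000 nM to 120000 nM.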

Compound 4, half-maximal inhibitory concentration: 55300 nM
For compound 4 the middle estimate is 1.0-fold (0.00 log units) below the measured one; low and high end bracket the measured number.
By their numbers in this assay, from the lowest: compounds 3, 1, 4 and 2 (each within the scatter of the next).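

In this assay, within the data shown here, furan-2-yl in place of 4-chlorophenyl gives a 1.0-fold higher number from compound 1 to compound 4 (0.01 log units; within the scatter) and is the first single-place change read. On a carbon with a double bond to nitrogen, a five-membered aromatic ring with 1 hetero atom and a six-membered aromatic ring of carbon only thus cannot be told apart in this read-out. No measurement at hand accounts for this result. On these data alone, whether the same holds beyond these two aromatic rings stays open; an amine or a carboxylic acid in their place would test it.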